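Methoxy added to the anilino ring of a thiazolyl acetamide

A few compounds are considered here, and "the series" means these few. Any claim that something is new, unique, unknown or untested is made for them only; others in the source may bear on it.

Compound 1 `Cc1nc(SCC(=O)Nc2nc(-c3ccc(Cl)cc3)cs2)n(Nc2ccccc2)c1C` is tested in a functional assay on SF-539 cells (Homo sapiens) for antiproliferative activity, read by sulforhodamine B assay, with a stated time of 48 h (on this read-out higher numbers stand for lower toxicity in this test and lower numbers for higher toxicity in this test), where compound 1 gives 9640 nM. This is the only number shown, and it sits beside one value that is a limit rather than a number. Compound 2 `Cc1ccc(Nn2c(SCC(=O)Nc3nc(-c4ccccc4)cs3)nc(C)c2C)cc1` differs from compound 1 in more than one place. In this assay compound 2 reaches only a limit, > 100000 nM, as stated in the limit of > 100000 nM in this assay, at which 1 of the 2 values shown sits. Compound 3 `COc1ccc(Nn2c(SCC(=O)Nc3nc(-c4ccc(Cl)cc4)cs3)nc(C)c2C)cc1` is not yet measured. It differs from compound 1 by methoxy in place of hydrogen on an aromatic carbon. For the measured compounds named here, no measured pair shows this exact change, so the expected step is uncertain; a modest move toward lower toxicity in this test is expected, with a fair chance that compound 3 also reports only a limit. Compound 3 is expected to give about 20000 nM, within 5000 nM to 100000 nM, a step of a 2.1-fold higher number from compound 1 to compound 3 (0.32 log units; beyond the scatter).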

Compound 3, concentration lethal to 50% of the cells: > 100000 nM
Compound 3 ended at the assay's limit; the forecaster's own chance of this, stated with the estimate: 35%; middle value at least 5.0-fold (0.69 log units) from the limit.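

Replacing hydrogen with methoxy on an aromatic carbon of the anilino ring, para to a large group, gives an at least 10-fold higher number from compound 1 to compound 3 (1.01 log units; beyond the scatter) in this assay. This is the first single change shown at this carbon, and it indicates that the measurable toxicity of compound 1 does not survive this addition. Compound 3 gives > 100000 nM, which is a limit of the assay and not a number, so the true size of the step remains unknown, and the read-out has reached its end here: the limit of > 100000 nM in this assay, at which 2 of the 3 values shown sit.

Going by these compounds, it remains open whether a smaller group on this carbon, such as fluorine or hydroxyl, would keep a measurable value. The compounds shown also give no reason for the step.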